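Adding a Second Trifluoromethyl to a Weakly Cytotoxic Amide

A few compounds are considered here, and "the series" means these few. Any claim that something is new, unique, unknown or untested is made for them only; others in the source may bear on it.

Two measured compounds set the scene in an ADME assay on HEK293 cells (Homo sapiens) for cytotoxicity, read by MTT assay, with a stated time of 48 h; on this read-out lower numbers stand for stronger inhibition and higher numbers for weaker inhibition. Compound 1 `Cc1cc(NC(=O)c2cc(C(F)(F)F)cc(C(F)(F)F)c2)ccc1NS(C)(=O)=O` gives 163000 nM in this assay. On these data alone, compound 2 `COc1cc(NC(=O)c2cccc(C(F)(F)F)c2)ccc1NS(C)(=O)=O` gives only a limit in this assay, > 250000 nM, so its exact value is unknown; it is one of the values described by the limit of > 250000 nM in this assay, at which 1 of the 2 values shown sits. Compound 3 `COc1cc(NC(=O)c2cc(C(F)(F)F)cc(C(F)(F)F)c2)ccc1NS(C)(=O)=O` is not yet measured. It differs from compound 2 by one change, (trifluoromethyl in place of hydrogen on an aromatic carbon), that is, trifluoromethyl in place of hydrogen on an aromatic carbon. For the measured compounds named here, no measured pair shows this single change, so no measured step can guide the expectation. Since compound 2 sits at the limit, the step from compound 2 to compound 3 in this assay is expected to lie within the scatter, an at least 1.2-fold lower number from compound 2 to compound 3 (0.09 log units; that floor lies within the scatter). Compound 3 is therefore expected to give about 200000 nM in this assay, likely between 100000 nM and 400000 nM.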

Compound 3, half-maximal inhibitory concentration: 42000 nM
Compound 3: middle estimate off by 4.8-fold (0.68 log units), on the high side, and the stated range ends above it.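

Placing a trifluoromethyl on this aromatic carbon, meta to a trifluoromethyl group, gives an at least 5.9-fold lower number from compound 2 to compound 3 (0.77 log units; beyond the scatter) in this assay, so a change at this position can move the read-out by more than the usual scatter. That step gives only a minimum size, because compound 2 carries a limit and not a number: the limit of > 250000 nM in this assay, at which 1 of the 3 values shown sits. With both trifluoromethyl groups present, a second place on the molecule also matters, as methoxy in place of methyl gives a 3.9-fold lower number from compound 1 to compound 3 (0.59 log units; beyond the scatter).

On these data alone, what remains open is whether this shift is specific to trifluoromethyl or would also appear with another group on the same carbon, such as a nitrile or a chlorine atom. For the compounds shown here, it is also unclear whether the methoxy and methyl swap would have the same effect in a compound with only one trifluoromethyl group.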